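Aryl to cycloalkylmethyl swap on the amide nitrogen

The source may hold more compounds than are shown below. What is called first, only, known or untested is meant among the compounds shown, and "the series" means these compounds.

Among the measured compounds shown here, compound 2 `O=C(Nc1ccc(Cl)cc1)c1cccc(N2C(=O)N/C(=C\c3ccc(O)cc3)C2=O)c1` is the only member of the series with a number in a functional assay on NCI-H292 cells (Homo sapiens) for antiproliferative activity; a higher number here means a weaker inhibitor, a lower number a stronger inhibitor: compound 2 gives 125000 nM. Compound 1 `O=C1N/C(=C\c2ccc(O)cc2)C(=O)N1c1cccc(Br)c1` gives only a limit in this assay, > 200000 nM. For the measured compounds named here, the one measured step, an at least 1.6-fold lower number from compound 1 to compound 2 (0.20 log units; that floor lies within the scatter), rests on that limit of > 200000 nM in this assay, at which 1 of the 2 values shown sits, and so sets only a floor that lies within the scatter. Compound 3 `O=C(NCC1CCCCC1)c1cccc(N2C(=O)N/C(=C\c3ccc(O)cc3)C2=O)c1` differs from compound 2 by cyclohexylmethyl in place of 4-chlorophenyl on an amide-type nitrogen. Going by the values given here, no measured step touches the substituent on the amide nitrogen itself; the step from compound 1 to compound 2 concerns the whole carbamoyl group and is anyway only a floor within the scatter. Nothing in the series supports a shift beyond the scatter in either direction. Compound 3 is therefore expected to give about 125000 nM, within 40000 nM to 400000 nM, and the step of no change at the digits printed from compound 2 to compound 3 (within the scatter) is expected to stay within the scatter.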

Compound 3, half-maximal inhibitory concentration: 17900 nM
Compound 3: the middle estimate sits 7.0-fold (0.84 log units) above what was measured; measured number outside the range, below it.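

In this assay, among the compounds shown here, the substituent on the amide-type nitrogen gives the first change that reads beyond the scatter: cyclohexylmethyl in place of 4-chlorophenyl gives a 7.0-fold lower number from compound 2 to compound 3 (0.84 log units; beyond the scatter) here. The number therefore responds to this substituent, which the earlier step, a floor within the scatter that concerned the whole carbamoyl group, could not show. The (cyclohexylmethyl)carbamoyl group in place of bromo gives an at least 11-fold lower number from compound 1 to compound 3 (1.04 log units; beyond the scatter) and this size is only a floor, as compound 1 stands at a limit: the limit of > 200000 nM in this assay, at which 1 of the 3 values shown sits.

The swap removes the chlorine, replaces the aromatic ring with a non-aromatic one and adds a methylene link together, so this pair cannot assign the step to any one of these. Open, as far as these compounds go, is how benzyl or cyclohexyl bonded directly to that nitrogen would read.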